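Benzylidene Succinimide Amides: Cytotoxicity on Colon Epithelial Cells

The source may report more compounds than this note shows. Statements on the series, on what has been measured and on what is new or still open speak of the compounds shown alone.

Compound 1 `O=C(Nc1ccccc1)c1cccc(/C=C2\CC(=O)N(c3ccccc3)C2=O)c1`: in an ADME assay on NCM460 cells (Homo sapiens) for cytotoxicity, read by MTT assay, with a stated time of 72 h (a lower number here means a stronger inhibitor, a higher number a weaker inhibitor), compound 1 gives > 100000 nM, which is a limit of the assay.
Compound 2 `O=C(c1cccc(/C=C2\CC(=O)N(c3ccccc3)C2=O)c1)N1CCCC1`: in this assay compound 2 gives > 100000 nM, which is a limit of the assay.

Compound 2 thus stands at the limit of the assay, as does compound 1. The step that the two limits leave unreadable from compound 1 to compound 2 cannot be read, because both values sit at the limit of > 100000 nM in this assay, at which 2 of the 2 values shown sit. Compound 3 `O=C(NCC1CCCCC1)c1cccc(/C=C2\CC(=O)N(c3ccccc3)C2=O)c1` differs from compound 2 by (cyclohexylmethyl)amino in place of pyrrolidin-1-yl on a carbonyl carbon. No measured step bears readably on this change; the only step shown is unreadable in size. The expectation for compound 3 is therefore a step of a number no higher from compound 2 to compound 3 (the limit leaves the size open) that is itself likely to remain hidden behind the limit, with no direction claimed. Compound 3 is estimated at 100000 nM, within a range from 40000 nM to 300000 nM.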

Compound 3, half-maximal inhibitory concentration: > 100000 nM
Compound 3 was reported as a limit; the forecaster's own chance of this, stated with the estimate: 80%; the middle value sits exactly at the limit.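

The steps among compound 1, compound 2 and compound 3 cannot be read in this assay, because all three values are limits of the assay: the limit of > 100000 nM in this assay, at which 3 of the 3 values shown sit.

On these data alone, whether the anilino, pyrrolidin-1-yl and (cyclohexylmethyl)amino groups differ at all in this read-out remains open.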